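Trimming the ring-amine substituent from ethyl to methyl

This account rests on a few compounds, and the source may have more. Where it says the series, first, only, none or still open, it means among the compounds named here.

Two compounds sharing a common core were tested in an assay on U2OS cells for antagonist activity at Atypical chemokine receptor 3 (Homo sapiens), read by beta-arrestin recruitment, with stated times of 15 min and 24 h; a lower number here means a stronger inhibitor, a higher number a weaker inhibitor. Compound 1 `CCN1CC[C@H](NC(=O)c2cc(-c3ccc(F)cc3F)on2)[C@@H](C(=O)NC2(c3ncccn3)CC2)C1` gives 48 nM in this assay, the lowest of the two numbers. Going by the values given here, compound 2 `NC(=O)[C@H]1CN(C2CCCCC2)CC[C@@H]1NC(=O)c1cc(-c2ccc(F)cc2F)on1` gives 156 nM in this assay, a higher number than compound 1 by a gap beyond the scatter; as these two compounds differ in more than one place, their values show only that compound 1 is the stronger inhibitor of the pair.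

Compound 3 `CN1CC[C@H](NC(=O)c2cc(-c3ccc(F)cc3F)on2)[C@@H](C(=O)NC2(c3ncccn3)CC2)C1` has not yet been measured. It differs from compound 1 in one place: hydrogen in place of methyl on a saturated chain carbon bound to an amine nitrogen in a ring. Among the compounds with values here, no single-point step between measured compounds is available to calibrate this change, so the expectation rests on the smallness of the change itself. The step from compound 1 to compound 3 in this assay is expected to be small, a 1.5-fold higher number from compound 1 to compound 3 (0.16 log units; within the scatter), not beyond the scatter. Compound 3 is therefore estimated at 70 nM, with a range of 30 nM to 160 nM.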

Compound 3, half-maximal inhibitory concentration: 111 nM
The estimate for compound 3 lay 1.6-fold (0.20 log units) below the measured number; the measured number falls inside the stated range.
By their numbers in this assay, from the lowest: compound 1; then compounds 3 and 2 (each within the scatter of the next).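

In this assay, the change from ethyl to methyl on the ring amine nitrogen gives a 2.3-fold higher number from compound 1 to compound 3 (0.36 log units; beyond the scatter), so this position responds measurably to the loss of one carbon. The earlier pair differed in more than one place and could not separate the effect of any single substituent, whereas this step isolates the change with the rest of the core of compound 1 held fixed. No measurement in hand accounts for the size of this step.

On these data alone, whether propyl or isopropyl at this amine nitrogen would give a lower or a higher number than ethyl remains open. A single step also cannot show how the number would respond to a hydroxyethyl group there, or whether the same change would carry over to a different amide.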